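Notes on a chloro for methyl exchange

This account rests on a few compounds, and the source may have more. Where it says the series, first, only, none or still open, it means among the compounds named here.

Measured in an ADME assay on Caco-2 cells (Homo sapiens) for permeability; on this read-out lower numbers stand for lower permeability and higher numbers for higher permeability:
- Compound 1 `C[C@H](CC(=O)N[C@@H]1O[C@H](CO)[C@@H](O)[C@H](O)[C@H]1O)c1ccc(C(C)(C)C)cc1`: 97.7 nm/s
- Compound 2 `Cc1ccc2c(c1)C=C(C(=O)N[C@@H]1O[C@H](CO)[C@@H](O)[C@H](O)[C@H]1O)C(=O)C2`: 36.2 nm/s

Compound 2 has the lower of the two numbers, and its gap to compound 1 lies beyond the scatter. Compound 3 `O=C1Cc2ccc(Cl)cc2C=C1C(=O)N[C@@H]1O[C@H](CO)[C@@H](O)[C@H](O)[C@H]1O` has chloro in place of methyl on an aromatic carbon. Within the data shown here, no measured pair differs in only one place, so the data offer no direct precedent for this exchange. In this assay, no step beyond the scatter is expected, and the direction remains uncertain. The expected step is a 1.1-fold higher number from compound 2 to compound 3 (0.04 log units; within the scatter). For compound 3 the estimated value is 40 nm/s, with an expected range of 18 nm/s to 85 nm/s.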

Compound 3, apparent permeability in the Caco-2 assay: 38.5 nm/s
Compound 3: middle estimate off by 1.0-fold (0.02 log units), on the high side; low and high end bracket the measured number.
By their numbers in the Caco-2 assay, from the lowest: compounds 2 and 3 (each within the scatter of the next); then compound 1.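

Among these compounds, in the Caco-2 assay compound 2 gives 36.2 nm/s and compound 3 gives 38.5 nm/s and chloro in place of methyl on this aromatic carbon gives a 1.1-fold higher number from compound 2 to compound 3 (0.03 log units; within the scatter), the first comparison that differs in one place. In a physicochemical assay for lipophilicity, measured as octanol-water partition (a lower number here means a more polar compound, a higher number a more lipophilic compound), compound 2 gives -0.451 and compound 3 gives -0.221 and the same exchange gives a number 0.23 log units higher from compound 2 to compound 3 (within the scatter), so neither read-out separates the two groups at this position.

As far as these compounds go, whether a larger change here, such as a nitrile or an amine on the same aromatic carbon, would separate the compounds in either read-out stays open. Nothing available gives a cause for the size of either step.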